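A few compounds are considered here, and "the series" means these few. Any claim that something is new, unique, unknown or untested is made for them only; others in the source may bear on it.

Measured compounds, in an assay on CHO cells for displacement of a labelled ligand from adenosine receptor A3 (Homo sapiens), read by scintillation counting, with a stated time of 120 min, tested at 10 uM; on this read-out higher numbers stand for more inhibition at the one concentration tested (going by the name of the read-out) and lower numbers for less inhibition:

compound 1, `Nc1scc(CN2CCN(c3ccccc3C(F)(F)F)CC2)c1C(=O)c1ccc(Cl)cc1` — compound 1 gives 0%
compound 2, `Nc1scc(CN2CCN(c3ccc(F)c(F)c3)CC2)c1C(=O)c1ccc(Cl)cc1` — compound 2 gives 1%

Among the compounds with values here, compound 2 and compound 1 cannot be told apart on these numbers: the only step so far, a number 1 percentage points higher from compound 1 to compound 2 (within the scatter), lies within the scatter, and both compounds sit at the bottom of the read-out with essentially no displacement at the single concentration tested.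

Compound 3, `Nc1scc(CN2CCN(c3ccc(F)c(Cl)c3)CC2)c1C(=O)c1ccc(Cl)cc1`, keeps the shared core of compound 2 and differs from it in one place: chloro in place of fluoro on an aromatic carbon. Within the data shown here, no measured step exchanges chloro for fluoro on this ring. Among the measured compounds shown here, the one step at hand, from compound 1 to compound 2, swaps the whole aryl group on the amine nitrogen and still produces nothing beyond the scatter, so the measured data give no sign that any change at this ring moves the read-out. The expectation for compound 3 is therefore no step beyond the scatter, a number 2 percentage points higher from compound 2 to compound 3 (within the scatter), with the number staying near the floor of the assay.

Estimated value for compound 3: 3%, range 0% to 15%.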

Compound 3, a percentage reported as inhibition, at one concentration (the size of the read-out at that concentration, not a potency): 0%
For compound 3 the middle estimate is 3 percentage points above the measured one, within the range that was stated.
By their numbers in this assay, from the lowest: compounds 1, 3 and 2 (each within the scatter of the next).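

In this assay, chloro in place of fluoro on an aromatic carbon, ortho to a fluoro group and meta to a large group, gives a number 1 percentage points lower from compound 2 to compound 3 (within the scatter) and so adds a single-halogen exchange at this position to the earlier exchange of the whole aryl group, again with no separation between the two compounds. The 3-chloro-4-fluorophenyl group in place of 2-(trifluoromethyl)phenyl on the amine nitrogen gives no change at the digits printed from compound 1 to compound 3 (within the scatter), so all three aryl groups shown on this nitrogen now read alike at the one concentration tested, close to the bottom of the read-out. Nothing at hand bears on why these three readings sit together.

Still open, as far as these compounds go, is whether any substituent on this aryl ring can lift the reading clear of the bottom of the scale, for example an amine or a carboxylic acid in place of the chloro. Also open, from the compounds shown here alone, is whether a change elsewhere on the shared core, such as a methoxy group in place of the chloro on the benzoyl ring, would give a reading that the aryl groups on the amine nitrogen could then be compared against.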